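The source may report more compounds than this note shows. Statements on the series, on what has been measured and on what is new or still open speak of the compounds shown alone.

The series shares one core, shown in compound 1 `CNC(=O)c1ccccc1Oc1nc(Nc2cccc(Br)c2)ncc1Br` and compound 2 `CNC(=O)c1ccccc1Oc1nc(Nc2ccc(Cl)cc2F)ncc1Br`. In a functional assay on MCF7 cells (Homo sapiens) for antiproliferative activity, read by MTT assay, with a stated time of 24 h (a lower number here means a stronger inhibitor, a higher number a weaker inhibitor), compound 1 gives 42500 nM. For compound 2 this assay reports only a limit, > 50000 nM, so compound 2 stands at the weak edge of what has been measured here. Going by the values given here, the single step between them, an at least 1.1-fold higher number from compound 1 to compound 2 (0.07 log units; that floor lies within the scatter), rests on that limit of > 50000 nM in this assay, at which 1 of the 2 values shown sits, and says no more than that the number for compound 2 is not lower than that of compound 1. The next compound, compound 3 `CNC(=O)c1ccccc1Oc1nc(Nc2cccc(C(C)C)c2)ncc1Br`, differs from compound 2 as follows: 3-isopropylphenyl in place of 4-chloro-2-fluorophenyl on a nitrogen on an aromatic ring. Among the compounds with values here, no measured step bears directly on this exchange; the only step available, from compound 1 to compound 2, concerns a different pair of groups on the same nitrogen and is itself within the scatter. Both measured compounds sit in the weak range, and nothing in the data points to the 3-isopropylphenyl group moving compound 3 out of it. Compound 3 is therefore expected at 45000 nM in this assay, within 20000 nM to 100000 nM, which amounts to an estimated step of an at least 1.1-fold lower number from compound 2 to compound 3 (0.04 log units; that floor lies within the scatter), with a fair chance that only a limit is reported again.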

Compound 3, half-maximal inhibitory concentration: 26500 nM
Compound 3: middle estimate off by 1.7-fold (0.23 log units), on the high side, within the range that was stated.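

The bromo and isopropyl groups can now be compared directly on the same phenyl ring, on a nitrogen on an aromatic ring, in this assay: isopropyl in place of bromo gives a 1.6-fold lower number from compound 1 to compound 3 (0.21 log units; within the scatter), so compound 1 and compound 3 cannot be told apart at this place. Exchange of the whole aryl group gives an at least 1.8-fold lower number from compound 2 to compound 3 (0.27 log units; that floor lies within the scatter), and this floor does not separate 3-isopropylphenyl from 4-chloro-2-fluorophenyl. Compound 2 has only a limit, so the full size of that step cannot be read: the limit of > 50000 nM in this assay, at which 1 of the 3 values shown sits.

The compounds shown leave open whether any group at this place can bring the number out of the weak range seen so far, for example an amine, a carboxylic acid or a longer chain in place of isopropyl. They also leave open what a change to the shared core would do in this assay, as compound 1, compound 2 and compound 3 all carry it unchanged.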